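Pyridin-3-yl to pyridin-4-yl step in a small series

The compounds below may be only part of what the source reports. "The series", "measured", "known", "first", "only" and "open" are said of these compounds alone.

Of the compounds shown here, three have numbers so far in a functional assay on SMMC-7721 cells (Homo sapiens) for cytotoxicity, read by MTT assay, with a stated time of 24 h; on this read-out higher numbers stand for weaker inhibition and lower numbers for stronger inhibition. Compound 3 `O=C1/C(=C/c2cccnc2)CNC/C1=C\c1ccccc1C(F)(F)F` gives 5100 nM, within the scatter of compound 1 `CN1C/C(=C\c2ccncc2)C(=O)/C(=C/c2ccccc2C(F)(F)F)C1` at 4100 nM. Compound 2 `O=C1/C(=C/c2ccncc2)CNC/C1=C\c1ccccc1F` gives 18400 nM, a higher number than compound 3 and beyond the scatter, so compound 3 sits with compound 1 at the low end of the three numbers.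

Compound 4 `O=C1/C(=C/c2ccncc2)CNC/C1=C\c1ccccc1C(F)(F)F` follows from compound 3 by a single change, (pyridin-4-yl in place of pyridin-3-yl on a double-bonded chain carbon bound to a double-bonded ring carbon), with pyridin-4-yl in place of pyridin-3-yl on a double-bonded chain carbon bound to a double-bonded ring carbon. Within the data shown here, no measured pair isolates this change, so its size rests on indirect evidence only. Compound 1 carries pyridin-4-yl and a trifluoromethyl group and gives 4100 nM, close to the number of compound 3, which carries pyridin-3-yl and a trifluoromethyl group. Compound 2 also carries pyridin-4-yl yet gives 18400 nM, so that group alone does not settle the number. In this assay, no step beyond the scatter is expected in either direction. The estimated change is a 1.1-fold lower number from compound 3 to compound 4 (0.05 log units; within the scatter). For compound 4 the estimate is 4500 nM, with an expected range of 2000 nM to 10000 nM.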

Compound 4, half-maximal inhibitory concentration: 4500 nM
Estimate against measurement, compound 4: no gap at the digits printed; the range from low to high includes it.
By their numbers in this assay, from the lowest: compounds 1, 4 and 3 (each within the scatter of the next); then compound 2.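

In this assay, the pair compound 3 and compound 4 isolates pyridin-4-yl in place of pyridin-3-yl on a double-bonded chain carbon bound to a double-bonded ring carbon, and the step is a 1.1-fold lower number from compound 3 to compound 4 (0.05 log units; within the scatter), so this pair does not separate the two groups. Among these compounds, compound 4 also provides single-place readings at two other sites: trifluoromethyl in place of fluoro on an aromatic carbon gives a 4.1-fold lower number from compound 2 to compound 4 (0.61 log units; beyond the scatter), the only one of the three steps beyond the scatter, while hydrogen in place of methyl on an amine nitrogen in a ring gives a 1.1-fold higher number from compound 1 to compound 4 (0.04 log units; within the scatter). The higher number of compound 2 therefore goes with fluoro in its pair with compound 4, and pyridin-4-yl is common to both members of that pair.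

No measurement on hand accounts for the size of any of these steps. The compounds shown leave open whether the flat result at this place extends to pyridin-2-yl, or to phenyl bearing an amine or a carboxylic acid, and whether it holds with fluoro in place of trifluoromethyl.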